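Swapping a Branched Chain for Methoxymethyl

The source may hold more compounds than are shown below. What is called first, only, known or untested is meant among the compounds shown, and "the series" means these compounds.

Measured so far:
compound 1, `CCC(=O)Nc1c(C(O)(C(F)(F)F)C(F)(F)F)ccc2ccccc12`: 15 nM
compound 2, `CCCC(C)C(=O)Nc1c(C(O)(C(F)(F)F)C(F)(F)F)ccc2ccccc12`: > 10000 nM (a limit, not a number)

In an assay on LtK cells with ATP-sensitive inward rectifier potassium channel 11 (Homo sapiens) as the target (on this read-out higher numbers stand for an effect only at larger amounts of compound and lower numbers for an effect already at smaller amounts), compound 1 gives 15 nM. Compound 2 stands at the limit of > 10000 nM in this assay, at which 1 of the 2 values shown sits, so only a limit and no number is known for it. Within the data shown here, the one measured step is an at least 660-fold higher number from compound 1 to compound 2 (2.82 log units; beyond the scatter): adding a propyl to the chain carbon bound to the carbonyl pushed the effect out of the measured range.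

Compound 3, `COCC(=O)Nc1c(C(O)(C(F)(F)F)C(F)(F)F)ccc2ccccc12`, differs from compound 2 by methoxymethyl in place of 1-methylbutyl on a carbonyl carbon. The entering group has three heavy atoms where the leaving group has five, so compound 3 carries a chain closer in size to that of compound 1 than to that of compound 2. The measured step ran towards a weaker effect as the chain grew; the step to compound 3 goes the other way and is expected to be large, back towards the number of compound 1, as an at least 250-fold lower number from compound 2 to compound 3 (2.39 log units; beyond the scatter). For compound 3 the estimate in this assay is 40 nM, ranging from 8 nM to 400 nM.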

Compound 3, half-maximal effective concentration: 213 nM
Estimate against measurement, compound 3: 5.3-fold (0.73 log units) below, within the range that was stated.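

In this assay, replacing 1-methylbutyl with methoxymethyl on the carbonyl carbon brings the result back into the measured range, an at least 46-fold lower number from compound 2 to compound 3 (1.67 log units; beyond the scatter), so this position still tolerates a chain other than the small one in compound 1. The size of that step is only a bound, since one end of it is a limit and not a number: the limit of > 10000 nM in this assay, at which 1 of the 3 values shown sits. The other new step, with methoxy in place of methyl on the chain carbon bound to the carbonyl carbon, has real numbers at both ends, a 14-fold higher number from compound 1 to compound 3 (1.15 log units; beyond the scatter), and shows that moving away from the much larger 1-methylbutyl recovers a great deal but does not by itself return the result to the level of the smallest chain.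

The change from 1-methylbutyl to methoxymethyl shortens the chain, removes its branch and adds an oxygen all at once, and these compounds cannot separate those three differences. Open too, as far as these compounds go, is how a plain unbranched propyl chain, an ethoxymethyl group or a dimethylaminomethyl group would read on the same carbonyl carbon.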